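The source may hold more compounds than are shown below. What is called first, only, known or untested is meant among the compounds shown, and "the series" means these compounds.

In an assay on isolated protein for inhibition of Rho-associated protein kinase 2 (Homo sapiens), read by scintillation counting, radiometric assay and 33P incorporation, with a stated time of 40 min, in the presence of a further agent that is not named here (a lower number here means a stronger inhibitor, a higher number a weaker inhibitor), three close relatives built on one shared core have been measured. Compound 1 `Cc1ccc(C(=O)Nc2cccc(NC(=O)COc3ccc4c(=O)ccoc4c3)c2)cc1` gives 22 nM. Compound 2 `CCCc1ccc(C(=O)Nc2cccc(NC(=O)COc3ccc4c(=O)ccoc4c3)c2)cc1` gives 14 nM, and compound 3 `O=C(COc1ccc2c(=O)ccoc2c1)Nc1cccc(NC(=O)c2ccc([N+](=O)[O-])cc2)c1` gives 15 nM. Among these three numbers compound 3 stands second highest, with compound 2 nearest and compound 1 furthest, yet every gap lies within the scatter: the step of a 1.6-fold lower number from compound 1 to compound 2 (0.20 log units; within the scatter), the step of a 1.5-fold lower number from compound 1 to compound 3 (0.17 log units; within the scatter) and the step of a 1.1-fold higher number from compound 2 to compound 3 (0.03 log units; within the scatter) all fall inside the usual repeat-to-repeat spread, so the three compounds cannot be ranked against one another.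

Compound 4 `O=C(COc1ccc2c(=O)ccoc2c1)Nc1cccc(NC(=O)c2cccc([N+](=O)[O-])c2)c1` has not yet been measured. It differs from compound 3 by 3-nitrophenyl in place of 4-nitrophenyl on a carbonyl carbon, so the same atoms are joined differently and nothing is gained or lost. Within the data shown here, none of the measured steps relocates a nitro group; each exchanges one group for another, and all were within the scatter, so no measured step bears directly on this change and the guidance is thin. With no step beyond the scatter among the relatives, the expectation for compound 4 in this assay is no change beyond the scatter, which as an expected step reads a 1.3-fold higher number from compound 3 to compound 4 (0.12 log units; within the scatter). Compound 4 is therefore estimated at 20 nM, with a range from 7 nM to 60 nM that is kept wide because a 1.1-fold higher number from compound 2 to compound 3 (0.03 log units; within the scatter) concerns a swap of groups rather than a relocation.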

Compound 4, half-maximal inhibitory concentration: 41 nM
For compound 4 the middle estimate is 2.1-fold (0.31 log units) below the measured one; measured number inside the range.
By their numbers in this assay, from the lowest: compounds 2, 3, 1 and 4 (each within the scatter of the next, the first and the last beyond it).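

Moving the nitro group, 3-nitrophenyl in place of 4-nitrophenyl on the carbonyl carbon, gives a 2.7-fold higher number from compound 3 to compound 4 (0.44 log units; beyond the scatter). Among these compounds, this is the first step in the set to pass the scatter, and it comes with no atom gained or lost, so at this position the arrangement of the same atoms can show up in the number even though exchanging one group for another among compounds 1, 2 and 3 did not. The picture is not clean, however: the exchange of 4-propylphenyl for 3-nitrophenyl gives a step of similar size, a 2.9-fold higher number from compound 2 to compound 4 (0.47 log units; beyond the scatter), while the exchange of 4-methylphenyl for 3-nitrophenyl gives a 1.9-fold higher number from compound 1 to compound 4 (0.27 log units; within the scatter), so compound 1 goes against any simple split between compound 4 and the other three, and nothing shown here accounts for the shift.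

Nitro is the only group seen in both arrangements, so it remains open whether methyl or propyl would move the number in the same way when shifted, or whether this step belongs to nitro alone. On these data alone, how an amine or a carboxylic acid in place of the nitro group would read in either arrangement also remains open.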